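This account rests on a few compounds, and the source may have more. Where it says the series, first, only, none or still open, it means among the compounds named here.

Compound 1 `O=C(NN1CCOCC1)c1c(O)c2cccnc2n(-c2ccccc2)c1=O` gives -26.2% in a functional assay on the whole organism for inhibition, with Rattus norvegicus as the target, read by cytopathic effect and paw edema, at a dose of 100 mg/kg by the oral route; on this read-out lower numbers stand for less inhibition and higher numbers for more inhibition at the one dose given (going by the name of the read-out). Compound 2 `COc1cccc(NC(=O)c2c(O)c3cccnc3n(-c3ccccc3)c2=O)c1` gives 20.7%. Compound 3 `O=C(Nc1cnccn1)c1c(O)c2cccnc2n(-c2ccccc2)c1=O` gives 21.2%.

Compound 3 thus has the highest of the three numbers, with compound 2 within the scatter of it and compound 1 far lower. Compound 4 `Cc1cnccc1NC(=O)c1c(O)c2cccnc2n(-c2ccccc2)c1=O` differs from compound 3 as follows: 3-methylpyridin-4-yl in place of pyrazin-2-yl on an amide-type nitrogen. The step that bears most on this change is a number 0.5 percentage points higher from compound 2 to compound 3 (within the scatter), a swap of one six-membered aromatic ring for another on the same amide-type nitrogen. The large steps of a number 46.9 percentage points higher from compound 1 to compound 2 (beyond the scatter) and a number 47.4 percentage points higher from compound 1 to compound 3 (beyond the scatter) concern morpholin-4-yl and say less here. Compound 4 is therefore expected to show a step of a number 1.2 percentage points lower from compound 3 to compound 4 (within the scatter), none beyond the scatter. The estimate for compound 4 is 20%, ranging from 4% to 36%.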

Compound 4, a percentage reported as inhibition, in the whole organism at one dose (the size of the read-out at that dose, not a potency): 8.8%
Beside the measured number, compound 4's estimate is 11.2 percentage points above it; low and high end bracket the measured number.
By their numbers in this assay, from the lowest: compound 1; then compound 4; then compounds 2 and 3 (each within the scatter of the next).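

On the amide-type nitrogen the six-membered aromatic rings are not interchangeable: 3-methylpyridin-4-yl in place of pyrazin-2-yl gives a number 12.4 percentage points lower from compound 3 to compound 4 (beyond the scatter), and in place of 3-methoxyphenyl it gives a number 11.9 percentage points lower from compound 2 to compound 4 (beyond the scatter), although the earlier swap between those two groups stayed within the scatter. The new ring still stands clear of morpholin-4-yl, with a number 35 percentage points higher from compound 1 to compound 4 (beyond the scatter). No measurement at hand accounts for these steps.

The compounds shown leave open whether the fall follows the methyl group or the ring itself, a question that pyridin-4-yl without the methyl would address. They also leave open how a carboxylic acid or a longer chain on the amide-type nitrogen would read out.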